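Chloro for Fluoro on a Fused Aromatic Core

This account rests on a few compounds, and the source may have more. Where it says the series, first, only, none or still open, it means among the compounds named here.

Compound 1 `CCS(=O)(=O)Nc1cc(F)cc2c1CCCC2c1c[nH]cn1` gives 3630 nM in an assay on isolated protein for binding affinity to Alpha-1D adrenergic receptor (Rattus norvegicus), read by radioligand binding; on this read-out lower numbers stand for stronger inhibition and higher numbers for weaker inhibition. Compound 2 `CCS(=O)(=O)Nc1cc(Cl)cc2c1CCCC2c1c[nH]cn1` differs by chloro in place of fluoro on an aromatic carbon and gives 363 nM, a step of a 10-fold lower number from compound 1 to compound 2 (1.00 log units; beyond the scatter). Compound 3 `CS(=O)(=O)Nc1ccc(F)c2c1CCCC2c1c[nH]cn1` gives 3020 nM; the difference between the core of compound 3 and the core of compound 1 is not broken down here. Compound 4 `CS(=O)(=O)Nc1ccc(Cl)c2c1CCCC2c1c[nH]cn1` differs from compound 3 by chloro in place of fluoro on an aromatic carbon. This is the same kind of change as from compound 1 to compound 2, but not the same: in compound 3 the place is ortho to a fused ring and para to a methanesulfonamido group, whereas in compound 1 it is meta to a (ethylsulfonyl)amino group and para to a fused ring. Resting on a 10-fold lower number from compound 1 to compound 2 (1.00 log units; beyond the scatter), a somewhat smaller step is expected, a 5.0-fold lower number from compound 3 to compound 4 (0.70 log units; beyond the scatter). Compound 4 is estimated at 600 nM, within 150 nM to 2000 nM.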

Compound 4, inhibition constant: 2880 nM
Beside the measured number, compound 4's estimate is 4.8-fold (0.68 log units) below it; the measured number lies above the stated range.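

On the core of compound 3, chloro in place of fluoro gives a 1.0-fold lower number from compound 3 to compound 4 (0.02 log units; within the scatter) in this assay. The change therefore does not carry over at one size between these two cores: the same change on two cores in this assay, a 10-fold lower number (1.00 log units; beyond the scatter) from compound 1 to compound 2 and a 1.0-fold lower number (0.02 log units; within the scatter) from compound 3 to compound 4, 9.5-fold (0.98 log units) apart, beyond the scatter of two such steps

This shows that the step is not a fixed increment in this series, but it does not show what sets it apart, since the two pairs differ both in the place of the halogen and in carrying an (ethylsulfonyl)amino or a methanesulfonamido group, and two pairs support no general rule.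

The compounds shown leave open whether either difference alone would shrink the step. They also leave open how a bromo or a methoxy group would read in the same places.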